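The source may hold more compounds than are shown below. What is called first, only, known or untested is meant among the compounds shown, and "the series" means these compounds.

Measured so far:
compound 1, `CCNCc1ccc(Cl)c(-c2ccccc2OC)c1` — "not active" (no number reported) in a functional assay on HEK293 cells for agonist activity at 5-hydroxytryptamine receptor 7 (Homo sapiens), read by a luciferase reporter and beta-arrestin recruitment, with a stated time of 22 h; a lower number here means a smaller maximal response, a higher number a larger maximal response
compound 2, `COc1ccccc1-c1cc(CN(C)C)ccc1Cl` — 43% in this assay

Compound 2 stands alone on the numbers: in this assay compound 2 gives 43%, and that is the only numerical result in this set. Compound 1 has no number in this assay, being reported as "not active" (no number reported), so nothing can be said about the size of any gap between compound 1 and compound 2.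

Compound 3, `CCCCNCc1ccc(Cl)c(-c2ccccc2OC)c1`, has not yet been measured. It differs from compound 2 in one place: butylamino in place of dimethylamino on a saturated chain carbon bound to an aromatic carbon. Since no step between two measured compounds is available, the direction and size of the change must be estimated from what little is shown. Because compound 1 gives "not active" (no number reported) and compound 2 gives 43%, a step downward is expected, and for compound 3 the expected step is a number 23 percentage points lower from compound 2 to compound 3 (beyond the scatter). For compound 3 the estimated maximal response in this assay is therefore 20%, in a range from 0% to 45%.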

Compound 3, largest response reached (Emax), in percent of the reference or control that the assay uses: "not active" (no number reported)
Compound 3 has no reported number here; the estimate stays without a comparison.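

Compound 3 has no number in this assay, so no step can be read between compound 2 and compound 3. Nothing available bears on this result. The compounds shown leave open whether any group other than dimethylamino, on this saturated chain carbon, can give a measurable maximal response.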